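Aryl variation on the shared core

This account rests on a few compounds, and the source may have more. Where it says the series, first, only, none or still open, it means among the compounds named here.

Compound 1 `CCOc1ccc(-c2cc(=O)c3c(o2)C(CC)(CC)C(=O)C(CC)=C3O)cc1` gives 7.54 uM in a functional assay on KBVIN cells (Homo sapiens) for antiproliferative activity, read by sulforhodamine B assay, with a stated time of 3 days (on this read-out higher numbers stand for an effect only at larger amounts of compound and lower numbers for an effect already at smaller amounts), the second highest of three numbers and within the scatter of both compound 2 `CCC1=C(O)c2c(oc(-c3cc(C)c(C)cc3C)cc2=O)C(CC)(CC)C1=O` at 4.37 uM and compound 3 `CCC1=C(O)c2c(oc(-c3cc(C)c(OC)cc3C)cc2=O)C(CC)(CC)C1=O` at 7.58 uM. Compound 4 `CCC1=C(O)c2c(oc(-c3ccc(O)c(C)c3C)cc2=O)C(CC)(CC)C1=O` carries 4-hydroxy-2,3-dimethylphenyl in place of 4-ethoxyphenyl on an aromatic carbon. Within the data shown here, two measured steps bear on this change: a 1.7-fold lower number from compound 1 to compound 2 (0.24 log units; within the scatter) and a 1.7-fold higher number from compound 2 to compound 3 (0.24 log units; within the scatter). Both exchanges of one aryl group for another with small substituents stayed within the scatter, and nothing among these three compounds points to a step beyond it for compound 4. The expected step from compound 1 is a 1.2-fold lower number from compound 1 to compound 4 (0.06 log units; within the scatter). Compound 4 is therefore estimated at 6.5 uM, with a range of 3 uM to 14 uM.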

Compound 4, concentration for half-maximal effect: 2.75 uM
Beside the measured number, compound 4's estimate is 2.4-fold (0.37 log units) above it, and the stated range ends above it.
By their numbers in this assay, from the lowest: compounds 4, 2, 1 and 3 (each within the scatter of the next, the first and the last beyond it).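

Among these compounds, the 4-hydroxy-2,3-dimethylphenyl group gives the first change of aryl group here that lies beyond the scatter, a 2.7-fold lower number from compound 1 to compound 4 (0.44 log units; beyond the scatter). Against the 2,4,5-trimethylphenyl group the same aryl group stays within it, a 1.6-fold lower number from compound 2 to compound 4 (0.20 log units; within the scatter), so compound 2 and compound 4 cannot be ordered. No measurement shown accounts for either step.

Open, from the compounds shown here alone, is whether the hydroxy group or the methyl groups of compound 4 carry the step from compound 1. Also open, going by these compounds, is how an amine or a carboxylic acid in place of that hydroxy group would read.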